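A few compounds are considered here, and "the series" means these few. Any claim that something is new, unique, unknown or untested is made for them only; others in the source may bear on it.

Measured in a functional assay on QGY-7703 cells (Homo sapiens) for cytotoxicity, read by MTT assay, with a stated time of 24 h; a higher number here means a weaker inhibitor, a lower number a stronger inhibitor:
- compound 1 `O=C1/C(=C/c2cccnc2)CN(S(=O)(=O)c2ccc([N+](=O)[O-])cc2)C/C1=C\c1ccccc1F`: 5600 nM
- compound 2 `O=C1/C(=C/c2cccnc2)CN(S(=O)(=O)c2ccc([N+](=O)[O-])cc2)C/C1=C\c1ccccc1C(F)(F)F`: 7660 nM

Going by the values given here, only two compounds have been measured in this assay, so the position of compound 2 at 7660 nM rests on a single comparison. It lies within the scatter of compound 1, at 5600 nM.

Compound 3 `N#Cc1ccc(S(=O)(=O)N2C/C(=C\c3cccnc3)C(=O)/C(=C/c3ccccc3C(F)(F)F)C2)cc1` differs from compound 2 in one place: cyano in place of nitro on an aromatic carbon. Nitro leaves and cyano enters at that place, which is para to a large group.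

Among the compounds with values here, no measured step covers this exchange. The only one available, a 1.4-fold higher number from compound 1 to compound 2 (0.14 log units; within the scatter), involves trifluoromethyl in place of fluoro, so it bears on the change only indirectly. It shows a change elsewhere on the molecule staying within the scatter. No step beyond the scatter is therefore expected, in either direction.

The expected result is a 1.1-fold lower number from compound 2 to compound 3 (0.04 log units; within the scatter). For compound 3 the estimated value is 7000 nM, with an expected range of 2500 nM to 20000 nM.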

Compound 3, half-maximal inhibitory concentration: 6150 nM
Compound 3: middle estimate off by 1.1-fold (0.06 log units), on the high side; low and high end bracket the measured number.
By their numbers in this assay, from the lowest: compounds 1, 3 and 2 (each within the scatter of the next).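

Exchanging nitro for cyano at this place, on an aromatic carbon para to a large group, gives a 1.2-fold lower number from compound 2 to compound 3 (0.10 log units; within the scatter) in this assay. Going by these compounds alone, the only earlier step concerned a change elsewhere on the molecule, so this is the first reading at the sulfonyl-bearing aryl group, and it shows that nitro can be replaced there without a step beyond the scatter. No measurement bears on why the number holds across this exchange.

On these data alone, whether this place accepts a group of a different kind remains open, since an amine, a carboxylic acid or a methoxy group there might or might not move the number beyond the scatter. As far as these compounds go, it is also open whether the same exchange of nitro for cyano would give a similar step with fluoro in place of trifluoromethyl on the other side of the molecule.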